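This account rests on a few compounds, and the source may have more. Where it says the series, first, only, none or still open, it means among the compounds named here.

Compounds measured in a functional assay on A549 cells (Homo sapiens) for inhibition, read by MTT assay, with a stated time of 72 h; a higher number here means a weaker inhibitor, a lower number a stronger inhibitor:
- compound 1, `CN(C(=O)NC(=O)c1cccc(C(F)(F)F)c1)c1nc(C(F)(F)F)c(C(=O)N/N=C/c2ccc(C(F)(F)F)cc2)s1` — 6.2 ug/mL
- compound 2, `CN(C(=O)NC(=O)c1c(F)cccc1F)c1nc(C(F)(F)F)c(C(=O)N/N=C/c2cccc(C(F)(F)F)c2)s1` — 27.6 ug/mL
- compound 3, `CN(C(=O)NC(=O)c1ccc(C(F)(F)F)cc1)c1nc(C(F)(F)F)c(C(=O)N/N=C/c2ccc(C(F)(F)F)cc2)s1` — > 100 ug/mL

Compound 3 stands at the weak end of the three. Its result in this assay is a limit of the assay rather than a number (the limit of > 100 ug/mL in this assay, at which 1 of the 3 values shown sits), so all that is known is that it is a weak inhibitor here. Compound 4, `CN(C(=O)NC(=O)c1c(F)cccc1F)c1nc(C(F)(F)F)c(C(=O)N/N=C/c2ccc(C(F)(F)F)cc2)s1`, is not yet measured. It differs from compound 3 in one place: 2,6-difluorophenyl in place of 4-(trifluoromethyl)phenyl on a carbonyl carbon.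

Among the compounds with values here, only one measured step bears on this part of the molecule: an at least 16-fold higher number from compound 1 to compound 3 (1.20 log units; beyond the scatter). That step shows that changing the aryl group on this carbonyl carbon can shift the result by a large amount, though it concerns a different pair of groups. The same 2,6-difluorophenyl that enters in compound 4 is carried, with differences elsewhere, by compound 2, and in this assay compound 2 gives 27.6 ug/mL, a measurable value. On that basis the step from compound 3 to compound 4 is expected to be a decrease in the number, an at least 2.5-fold lower number from compound 3 to compound 4 (0.39 log units; beyond the scatter), though only a limit is known for the starting point. Compound 4 is therefore estimated at 40 ug/mL, within a range of 10 ug/mL to 150 ug/mL.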

Compound 4, half-maximal inhibitory concentration: 40.1 ug/mL
For compound 4 the middle estimate is 1.0-fold (0.00 log units) below the measured one, within the range that was stated.
By their numbers in this assay, from the lowest: compound 1; then compounds 2 and 4 (each within the scatter of the next). At a limit, above all of these: compound 3.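

In this assay, compound 3 sits at a limit of the assay rather than at a number, so an at least 2.4-fold lower number from compound 3 to compound 4 (0.39 log units; beyond the scatter) is only a bound, yet it shows that 2,6-difluorophenyl on this carbonyl carbon gives a measurable result where 4-(trifluoromethyl)phenyl does not. Set against the third group tried at this place on the same core, a 6.5-fold higher number from compound 1 to compound 4 (0.81 log units; beyond the scatter), which places 2,6-difluorophenyl between 3-(trifluoromethyl)phenyl and 4-(trifluoromethyl)phenyl, with each gap beyond the usual scatter. On a carbon with a double bond to nitrogen, 4-(trifluoromethyl)phenyl in place of 3-(trifluoromethyl)phenyl gives a 1.5-fold higher number from compound 2 to compound 4 (0.16 log units; within the scatter), so the swap that matters so much on the carbonyl carbon depends strongly on where it is made: the same change on two cores in this assay, an at least 16-fold higher number (1.20 log units; beyond the scatter) from compound 1 to compound 3 and a 1.5-fold higher number (0.16 log units; within the scatter) from compound 2 to compound 4, at least 11-fold (1.04 log units) apart, beyond the scatter of two such steps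

From the compounds shown here alone, it remains open how a plain phenyl, or a phenyl carrying an amine or a carboxylic acid, would score on this carbonyl carbon. Also open, going by these compounds, is whether the order of the three groups holds when the carbon with a double bond to nitrogen carries 3-(trifluoromethyl)phenyl, since only compound 2 offers a reading on that side.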